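This account rests on a few compounds, and the source may have more. Where it says the series, first, only, none or still open, it means among the compounds named here.

Working notes on the series built on the shared core of compound 1 `OC(CCn1nc2c(Br)c(Br)c(Br)c(Br)c2n1)c1cccc(Br)c1`. In a functional assay on MCF7 cells (Homo sapiens) for antiproliferative activity, read by MTT assay, with a stated time of 48 h, tested at 12.5 uM (a higher number here means a weaker effect of the compound at the concentration tested, a lower number a stronger effect), compound 1 gives 102%. Within the data shown here, compound 2 `OC(CCn1nc2c(Br)c(Br)c(Br)c(Br)c2n1)c1cccc(Cl)c1` gives 107% in this assay; the only one-place step measured so far, a number 5 percentage points higher from compound 1 to compound 2 (within the scatter), lies within the scatter. Compound 3 `C[C@@H](O)CCn1nc2c(Br)c(Br)c(Br)c(Br)c2n1` gives 86% in this assay, the lowest of the three numbers, and both compound 1 and compound 2 stand higher than it by more than the scatter.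

Compound 4 `OCC(O)Cn1nc2c(Br)c(Br)c(Br)c(Br)c2n1` differs from compound 3 in one place: 1,2-dihydroxyethyl in place of 2-hydroxypropyl on a saturated chain carbon bound to an aromatic nitrogen. Among the measured compounds shown here, no measured step touches the chain on the aromatic nitrogen; the single step measured, a number 5 percentage points higher from compound 1 to compound 2 (within the scatter), concerns a halogen on an aromatic carbon and was within the scatter, so it gives no direction for the present change. What the series does show is that the smaller chain of compound 3 gives a lower number than the larger substituents of compound 1 and compound 2, and compound 4 keeps a chain of the same size as compound 3.

For compound 4 the step of a number 4 percentage points higher from compound 3 to compound 4 (within the scatter) is therefore expected to stay within the scatter. Compound 4 is estimated at 90% in this assay, with a range from 74% to 106%.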

Compound 4, a percentage reported as activity, at one concentration (the size of the read-out at that concentration, not a potency): 116%
Compound 4: middle estimate off by 26 percentage points, on the low side; the measured number lies above the stated range.
By their numbers in this assay, from the lowest: compound 3; then compounds 1, 2 and 4 (each within the scatter of the next, the first and the last beyond it).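

In this assay the change to 1,2-dihydroxyethyl in place of 2-hydroxypropyl gives a number 30 percentage points higher from compound 3 to compound 4 (beyond the scatter), the first step beyond the scatter at this place on a saturated chain carbon bound to an aromatic nitrogen, and the only step shown that touches the chain. Both groups hold 4 heavy atoms, so the step shows that this place responds to a change that leaves the heavy-atom count as it is: 2 carbon and 2 oxygen enter for 3 carbon and 1 oxygen, 2 hydrogen-bond donors and 2 acceptors for 1 of each, and the defined stereocentre of the 2-hydroxypropyl group goes. Nothing on hand gives a cause for this step.

From the compounds shown here alone, these differences arrive together in one step, so how much of the higher number belongs to the second hydroxyl group and how much to the loss of the defined stereocentre stays open. Also open, going by these compounds, is what an amine or a carboxylic acid in this place would give, and what a longer chain carrying the same two hydroxyl groups would give.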